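The source may hold more compounds than are shown below. What is called first, only, known or untested is meant among the compounds shown, and "the series" means these compounds.

In a functional assay on MCF7 cells (Homo sapiens) for cytotoxicity, read by MTT assay, with a stated time of 96 h (on this read-out higher numbers stand for weaker inhibition and lower numbers for stronger inhibition), compound 1 `COc1cc(C(=O)c2cn(-c3cccc(C)c3)cc2-c2ccccc2F)cc(OC)c1OC` gives 190 nM and compound 2 `COc1cc(C(=O)c2cn(-c3cccc(C)c3)cc2-c2cccc([N+](=O)[O-])c2)cc(OC)c1OC` gives 880 nM while compound 3 `COc1cc(C(=O)c2cn(-c3cccc(N)c3)cc2-c2ccccc2F)cc(OC)c1OC` gives 17 nM as the lowest of the three numbers, beyond the scatter from both others. Compound 4 `COc1cc(C(=O)c2cn(-c3cccc(N)c3)cc2-c2cccc([N+](=O)[O-])c2)cc(OC)c1OC` is not yet measured. Relative to compound 3 it carries 3-nitrophenyl in place of 2-fluorophenyl on an aromatic carbon with 3-nitrophenyl in place of 2-fluorophenyl on an aromatic carbon. The same exchange has one measured precedent in a 4.6-fold higher number from compound 1 to compound 2 (0.67 log units; beyond the scatter) and that step is modest and beyond the scatter. The other measured step is an 11-fold lower number from compound 1 to compound 3 (1.05 log units; beyond the scatter) which is large, but this amino in place of methyl change is present in both compound 3 and compound 4 and does not separate them. For the measured compounds named here, only one pair shows the exchange, and the data do not yet show whether it carries over unchanged when amino replaces methyl. A modest rise in the number is therefore expected, with an estimated 4.7-fold higher number from compound 3 to compound 4 (0.67 log units; beyond the scatter) in this assay as the working figure. Compound 4 is estimated at 80 nM with 28 nM to 230 nM as the expected range.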

Compound 4, half-maximal inhibitory concentration: 510 nM
For compound 4 the middle estimate is 6.4-fold (0.80 log units) below the measured one, outside the stated range (above it).
By their numbers in this assay, from the lowest: compound 3; then compound 1; then compounds 4 and 2 (each within the scatter of the next).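

In this assay, the exchange of 2-fluorophenyl for 3-nitrophenyl at this position does not have a fixed size; it depends on the group at the other end of the shared core, and beside the 3-aminophenyl group it gives a 30-fold higher number from compound 3 to compound 4 (1.48 log units; beyond the scatter), clearly more than on the core of compound 1: the same change on two cores in this assay, a 4.6-fold higher number (0.67 log units; beyond the scatter) from compound 1 to compound 2 and a 30-fold higher number (1.48 log units; beyond the scatter) from compound 3 to compound 4, 6.5-fold (0.81 log units) apart, beyond the scatter of two such steps.
Read the other way, amino in place of methyl, large with 2-fluorophenyl present, gives only a 1.7-fold lower number from compound 2 to compound 4 (0.24 log units; within the scatter) with 3-nitrophenyl present: the same change on two cores in this assay, an 11-fold lower number (1.05 log units; beyond the scatter) from compound 1 to compound 3 and a 1.7-fold lower number (0.24 log units; within the scatter) from compound 2 to compound 4, 6.5-fold (0.81 log units) apart, beyond the scatter of two such steps.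
Among these four compounds, the low number appears only where amino and 2-fluorophenyl occur together, in compound 3 at 17 nM.

On these data alone, it remains open whether a plain phenyl or a nitrile-bearing phenyl at this position would keep the amino gain. As far as these compounds go, it is also open whether a hydroxyl or a dimethylamino group in place of amino would depend on this position in the same way.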